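This account rests on a few compounds, and the source may have more. Where it says the series, first, only, none or still open, it means among the compounds named here.

Measured compounds:

Compound 1 `CS(=O)(=O)C1CCN(C(=O)CCSc2nc3cc(Cl)ccc3o2)C1`: in an ADME assay on microsomes from liver (Homo sapiens) for metabolic stability, read by LC-MS, using NADPH, with a stated time of 45 min, tested at 0.5 uM (a lower number here means slower removal, a higher number faster removal of the compound), compound 1 returns only a limit, < 0.4 mL/min/g.
Compound 2 `CS(=O)(=O)C1CCN(C(=O)CCSc2nc3cc(Cl)ccc3o2)CC1`: in this assay compound 2 gives 0.5 mL/min/g.
Compound 3 `O=C(CCSc1nc2cc(Cl)ccc2o1)N1CCCCC1`: in this assay compound 3 gives 10.7 mL/min/g.

Compound 3 holds the highest of the two numbers; its nearest neighbour is compound 2, and the step of a 21-fold higher number from compound 2 to compound 3 (1.33 log units; beyond the scatter) is large. Compound 1 sits at the limit of the assay (the limit of < 0.4 mL/min/g in this assay, at which 1 of the 3 values shown sits).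

Compound 4 `CCN(CC)C(=O)CCSc1nc2cc(Cl)ccc2o1` is not yet measured. Set against compound 3 it differs in one place: diethylamino in place of piperidin-1-yl on a carbonyl carbon. Among the measured compounds shown here, the only measured step concerns the methylsulfonyl group on the saturated ring, not the amine attached to the carbonyl carbon, so no measured step bears directly on this change. Both the leaving group and the entering group carry no hydrogen-bond donors or acceptors and no charge, and the expectation for compound 4 is therefore a step of a 1.1-fold lower number from compound 3 to compound 4 (0.03 log units; within the scatter) that stays within the scatter. Compound 4 is estimated at 10 mL/min/g, with a range from 4 mL/min/g to 25 mL/min/g.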

Compound 4, intrinsic clearance in a liver preparation (reported as CLH), per the amount of preparation that the assay uses: 5.9 mL/min/g
Compound 4: middle estimate off by 1.7-fold (0.23 log units), on the high side; the range from low to high includes it.
By their numbers in this assay, from the lowest: compound 2; then compounds 4 and 3 (each within the scatter of the next). At a limit, below all of these: compound 1.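

In this assay, among the compounds shown here, the step of a 1.8-fold lower number from compound 3 to compound 4 (0.26 log units; within the scatter) is the first measured change to the amine on the carbonyl carbon itself, as the earlier step concerned only the methylsulfonyl group on the saturated ring. Replacing piperidin-1-yl with diethylamino removes the ring at this place, yet the two numbers stay within the scatter of each other, so this one pair gives no sign that the closed ring matters in this assay. Nothing at hand accounts for the size of this step.

The compounds shown leave open how a morpholine ring or a dimethylamino group would read on the same carbonyl carbon. They also leave open whether methylsulfonyl on an ethyl chain of the diethylamino group would match the large 21-fold higher number from compound 2 to compound 3 (1.33 log units; beyond the scatter) seen on the ring, read in reverse.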